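A few compounds are considered here, and "the series" means these few. Any claim that something is new, unique, unknown or untested is made for them only; others in the source may bear on it.

Measured so far:
compound 1 `CO/C(O)=C1\C(C)=NC(C)=C(C(=O)OCCCN2C(=O)c3ccccc3S2(=O)=O)C1c1ccccc1[N+](=O)[O-]` gives 0.0817 h
compound 2 `CCO/C(O)=C1\C(C)=NC(C)=C(C(=O)OCCCN2C(=O)c3ccccc3S2(=O)=O)C1c1ccccc1C(F)(F)F` gives 0.155 h
compound 3 `COCCO/C(O)=C1\C(C)=NC(C)=C(C(=O)OCCCN2C(=O)c3ccccc3S2(=O)=O)C1c1ccccc1C(F)(F)F` gives 0.0717 h

In a functional assay on aorta with Voltage-dependent L-type calcium channel subunit alpha-1C (Oryctolagus cuniculus) as the target (on this read-out lower numbers stand for a shorter-lived compound and higher numbers for a longer-lived compound), compound 3 stands lowest of the three numbers, though its gap to compound 1 lies within the scatter; only compound 2 stands clearly higher. Compound 4 `CC1=NC(C)=C(C(=O)OCCCN2C(=O)c3ccccc3S2(=O)=O)C(c2ccccc2C(F)(F)F)/C1=C(\O)OCC1CCCCO1` differs from compound 3 by oxan-2-yl in place of methoxymethyl on a saturated chain carbon bound to an oxygen on an unsaturated carbon. Among the measured compounds shown here, one measured step bears on this place: a 2.2-fold lower number from compound 2 to compound 3 (0.33 log units; beyond the scatter), where a methoxy group entered the same side chain and the number fell modestly. The present change is larger and introduces a ring, and the data hold nothing that tells whether this lengthens or shortens the half-life. A modest step, direction uncertain, is therefore expected. Compound 4 is expected to give 0.09 h, within the range 0.04 h to 0.22 h. The expected step is a 1.3-fold higher number from compound 3 to compound 4 (0.10 log units; within the scatter).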

Compound 4, half-life: 0.0767 h
Compound 4: the middle estimate sits 1.2-fold (0.07 log units) above what was measured; the range from low to high includes it.
By their numbers in this assay, from the lowest: compounds 3, 4, 1 and 2 (each within the scatter of the next, the first and the last beyond it).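

In this assay, oxan-2-yl in place of methoxymethyl gives a 1.1-fold higher number from compound 3 to compound 4 (0.03 log units; within the scatter), so at this saturated chain carbon bound to an oxygen on an unsaturated carbon, adding a ring to the side chain changes the number no more than the scatter. Oxan-2-yl in place of methyl gives a 2.0-fold lower number from compound 2 to compound 4 (0.31 log units; beyond the scatter), so a second, quite different group stands clearly apart from the methyl, as methoxy did. Nothing measured here explains this. From the compounds shown here alone, whether an amine or a carboxylic acid at this place would read differently stays open. So does whether a longer chain would.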